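Halogen shift on the terminal anilide of a cyclopropane diamide

This account rests on a few compounds, and the source may have more. Where it says the series, first, only, none or still open, it means among the compounds named here.

Measured compounds:
compound 1, `CN(C)C(=O)c1cc2cnc(Nc3ccc(NC(=O)C4(C(=O)Nc5ccccc5)CC4)cc3)nc2n1C1CCCC1`, 95.9%
compound 2, `CN(C)C(=O)c1cc2cnc(Nc3ccc(NC(=O)C4(C(=O)Nc5ccccc5F)CC4)cc3)nc2n1C1CCCC1`, 93.1%
compound 3, `CN(C)C(=O)c1cc2cnc(Nc3ccc(NC(=O)C4(C(=O)Nc5ccc(Br)cc5)CC4)cc3)nc2n1C1CCCC1`, 96.4%

All three compounds were tested in a functional assay on NCI-H460 cells (Homo sapiens) for inhibition, read by CCK-8 assay, with a stated time of 72 h, tested at 10 uM; a higher number here means more inhibition of growth at the concentration tested, a lower number less inhibition of growth. Compound 1 gives 95.9%, compound 2 gives 93.1% and compound 3 gives 96.4%. Compound 3 stands alongside the other two: the step of a number 0.5 percentage points higher from compound 1 to compound 3 (within the scatter) and the step of a number 3.3 percentage points higher from compound 2 to compound 3 (within the scatter) are both within the scatter, so the three numbers cannot be told apart.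

Compound 4, `CN(C)C(=O)c1cc2cnc(Nc3ccc(NC(=O)C4(C(=O)Nc5cccc(Cl)c5)CC4)cc3)nc2n1C1CCCC1`, differs from compound 3 by 3-chlorophenyl in place of 4-bromophenyl on an amide-type nitrogen. The measured steps that bear on this are the halogen changes on the same phenyl ring: a number 2.8 percentage points lower from compound 1 to compound 2 (within the scatter), a number 0.5 percentage points higher from compound 1 to compound 3 (within the scatter) and a number 3.3 percentage points higher from compound 2 to compound 3 (within the scatter). None of them moved the read-out beyond the scatter, so a change of halogen and of its place on this ring is expected to leave this assay essentially unchanged.

Compound 4 is therefore expected to give 95%, with a range from 88% to 99%. The expected step of a number 1.4 percentage points lower from compound 3 to compound 4 (within the scatter) is estimated to lie within the scatter.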

Compound 4, percent growth inhibition at one concentration: 101%
Estimate against measurement, compound 4: 6 percentage points below; measured number above the stated range.
By their numbers in this assay, from the lowest: compounds 2, 1, 3 and 4 (each within the scatter of the next).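

With compound 4, a chloro group joins fluoro and bromo on this terminal phenyl ring, and in this assay all three new steps lie within the scatter: a number 5.1 percentage points higher from compound 1 to compound 4 (within the scatter) and a number 4.6 percentage points higher from compound 3 to compound 4 (within the scatter) and a number 7.9 percentage points higher from compound 2 to compound 4 (within the scatter). The 3-chlorophenyl group on the amide-type nitrogen therefore cannot be told apart from phenyl, 2-fluorophenyl or 4-bromophenyl there, so the four compounds form a single group with no order among them. No measurement at hand bears on why this ring accepts these changes.

The compounds shown leave open whether an amine such as dimethylamino or a carboxylic acid on this ring would also leave the number in place. A single test concentration also leaves open whether the four halogen variants would separate at lower concentrations.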